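From a diaryl urea to a carbamate pair

The compounds below may be only part of what the source reports. "The series", "measured", "known", "first", "only" and "open" are said of these compounds alone.

Compound 1 `CC(C)c1cccc(C(C)C)c1NC(=O)NC(=O)N1CCCC1`: > 5000 nM
Compound 2 `CC(C)c1cccc(C(C)C)c1OC(=O)NC(=O)OC(c1ccccc1)c1ccccc1`: 350 nM

In an assay on microsomes from intestine for inhibition of acyl-CoA:cholesterol acyltransferase (Oryctolagus cuniculus) (a lower number here means a stronger inhibitor, a higher number a weaker inhibitor), compound 1 reaches only a limit, > 5000 nM, where one of the two values sits (the limit of > 5000 nM in this assay, at which 1 of the 2 values shown sits). Compound 2 holds the only number shown, 350 nM. Compound 3 `COC(=O)C(OC(=O)NC(=O)Oc1c(C(C)C)cccc1C(C)C)c1ccccc1` differs from compound 2 by methoxycarbonyl in place of phenyl on a saturated chain carbon bound to an aromatic carbon and an oxygen next to a carbonyl group. Going by the values given here, no step between measured compounds is known, so the size of this change is untested. A weakening beyond the scatter, a 3.4-fold higher number from compound 2 to compound 3 (0.54 log units; beyond the scatter), is expected. Compound 3 is estimated at 1200 nM, between 300 nM and 5000 nM.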

Compound 3, half-maximal inhibitory concentration: 940 nM
Beside the measured number, compound 3's estimate is 1.3-fold (0.11 log units) above it; the range from low to high includes it.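

In this assay, methoxycarbonyl in place of phenyl on this saturated chain carbon gives a 2.7-fold higher number from compound 2 to compound 3 (0.43 log units; beyond the scatter). Going by these compounds alone, this is the only measured step at this position; it shows that the change weakens inhibition only modestly, and compound 3 still gives a number rather than a limit. Nothing measured here accounts for the size of this step. The compounds shown leave open how a carboxylic acid or an amine would fare on this carbon, and whether an ethoxycarbonyl group would differ from methoxycarbonyl.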